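Replacing the side group of compound 1

This account rests on a few compounds, and the source may have more. Where it says the series, first, only, none or still open, it means among the compounds named here.

Measured in a functional assay on A549 cells (Homo sapiens) for inhibition, read by MTT assay, with a stated time of 48 h; on this read-out lower numbers stand for stronger inhibition and higher numbers for weaker inhibition:
- compound 1 `COc1ccc(N(C)c2nc(C)nc3ccccc23)cc1C(=O)NCC[Se]C#N`: 187 nM
- compound 2 `Cc1nc(N(C)c2ccc(OCC[Se]C#N)cc2)c2ccccc2n1`: 893 nM

Compound 1 stands lowest of the two, with 187 nM against 893 nM for compound 2, a gap beyond the usual scatter of this assay. Compound 3 `COc1ccc(N(C)c2nc(C)nc3ccccc23)cc1C[Se]C#N` is not yet measured. It departs from compound 1 on an aromatic carbon, ortho to a methoxy group and meta to a large group: a group of 4 heavy atoms (2 carbon, 1 nitrogen, 1 selenium; no ring) in place of a group of 8 heavy atoms (4 carbon, 2 nitrogen, 1 oxygen, 1 selenium; no ring), on an aromatic carbon.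

Going by the values given here, no measured pair isolates this change, since compound 1 and compound 2 differ in more than one place. The expectation is therefore loose. A moderate move towards a higher number is expected, though a result within the scatter of compound 1 would not be surprising. The two values available, compound 1 at 187 nM and compound 2 at 893 nM, serve only as a rough frame, and a result outside them is allowed for. The expected size is a 1.9-fold higher number from compound 1 to compound 3 (0.27 log units; within the scatter). For compound 3 the estimated value is 350 nM, with an expected range of 100 nM to 1200 nM.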

Compound 3, half-maximal inhibitory concentration: 98 nM
For compound 3 the middle estimate is 3.6-fold (0.55 log units) above the measured one; measured number outside the range, below it.
By their numbers in this assay, from the lowest: compounds 3 and 1 (each within the scatter of the next); then compound 2.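

In this assay, going by these compounds alone, the one readable step at this position, an aromatic carbon ortho to a methoxy group and meta to a large group, is the exchange of the group of 8 heavy atoms for the group of 4 heavy atoms (a step of a 1.9-fold lower number from compound 1 to compound 3 (0.28 log units; within the scatter)). The earlier compounds shown here differed in more than one place and could not isolate this position; this pair shows that the read-out tolerates the change here, with no separation beyond the scatter. The group that leaves carries 1 hydrogen-bond donor, 1 double bond and 2 hydrogen-bond acceptors, and the group that enters carries no donor, no double bond and 1 acceptor, so in this pair those counts can fall without a clear shift in the number, and no measurement at hand says why the two groups read alike.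

The compounds shown leave open whether the selenium and nitrile are needed at this carbon, a question that an amine or a carboxylic acid in their place would address. They also leave open how a longer chain between the ring and the selenium would read in this assay.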